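From dimethylamino to dipropylamino on the chain

A few compounds are considered here, and "the series" means these few. Any claim that something is new, unique, unknown or untested is made for them only; others in the source may bear on it.

Compound 1 `CNCCNc1nnc(-c2ccccc2)cc1C` gives >= 30 mg/kg as a limit
Compound 2 `Cc1cc(-c2ccccc2)nnc1NCCN(C)C` gives > 30 mg/kg as a limit

In a functional assay on the whole organism for positive allosteric modulation, with Mus musculus as the target (on this read-out higher numbers stand for an effect only at larger amounts of compound and lower numbers for an effect already at smaller amounts), compound 2 stands at > 30 mg/kg and this is a limit and not a number. Compound 3 `CCCN(CCC)CCNc1nnc(-c2ccccc2)cc1C` differs from compound 2 by dipropylamino in place of dimethylamino on a saturated chain carbon, two bonds along the chain from a nitrogen on an aromatic ring and has not yet been measured. Going by the values given here, the one measured step is a step that the two limits leave unreadable from compound 1 to compound 2 and it offers no size to carry over. No step beyond the scatter and no direction can therefore be expected with any confidence. In this assay the expected step is a step that the limit leaves unreadable from compound 2 to compound 3 on this weak footing. Compound 3 is estimated at 35 mg/kg with 12 mg/kg to 100 mg/kg as the expected range.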

Compound 3, dose for half-maximal effect: > 30 mg/kg
Compound 3 was reported as a limit; the forecaster's own chance of this, stated with the estimate: 75%; the middle value does not contradict the limit.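

Going by these compounds alone, no step among compound 1, compound 2 and compound 3 can be read, as each of their values is a limit and not a number. The compounds shown leave open whether dipropylamino, dimethylamino and methylamino differ in effect at all.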